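The compounds below may be only part of what the source reports. "The series", "measured", "known", "first", "only" and "open" are said of these compounds alone.

Compound 1 `O=C1C=CC2(C=C1)OCC(=O)N2S(=O)(=O)c1ccc(OC(F)(F)F)cc1` carries a trifluoromethoxy group, and in a functional assay on A549 cells (Homo sapiens) for inhibition, read by sulforhodamine B assay, with a stated time of 74 h (a higher number here means a weaker inhibitor, a lower number a stronger inhibitor), compound 1 gives 40 nM. Compound 3 `O=C1C=CC2(C=C1)OCC(=O)N2S(=O)(=O)c1ccc(C(F)(F)F)cc1` differs from it by trifluoromethyl in place of trifluoromethoxy on an aromatic carbon, and the step of an at least 250-fold higher number from compound 1 to compound 3 (2.39 log units; beyond the scatter) is large. In this assay compound 3 reaches only the limit, > 10000 nM. Compound 2 `O=C1C=CC2(C=C1)OCC(=O)N2S(=O)(=O)c1ccccc1OC(F)(F)F` is built from the same atoms as compound 1, joined differently; the difference between the two cores is not broken down here. In this assay compound 2 likewise reaches only the limit, > 10000 nM. Compound 4 `O=C1C=CC2(C=C1)OCC(=O)N2S(=O)(=O)c1ccccc1C(F)(F)F` differs from compound 2 by trifluoromethyl in place of trifluoromethoxy on an aromatic carbon. For the measured compounds named here, this is the same kind of change as the one from compound 1 to compound 3, but here the place is ortho to a large group rather than para to a large group. Given that compound 2 already sits at the limit of > 10000 nM in this assay, at which 2 of the 3 values shown sit, the step expected is a step that the limit leaves unreadable from compound 2 to compound 4. Compound 4 is therefore expected to give about 30000 nM, somewhere between 10000 nM and 100000 nM.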

Compound 4, half-maximal inhibitory concentration: > 10000 nM
Compound 4: no number, only a limit; the forecaster's own chance of this, stated with the estimate: 90%; the middle value lies beyond the limit too.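

Compound 2 and compound 4 each give only a limit, so no step can be read between them: the limit of > 10000 nM in this assay, at which 3 of the 4 values shown sit. The compounds shown leave open whether trifluoromethoxy and trifluoromethyl differ at all when ortho to a large group.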